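This account rests on a few compounds, and the source may have more. Where it says the series, first, only, none or still open, it means among the compounds named here.

Values in a functional assay on HCT-116 cells (Homo sapiens) for antiproliferative activity, read by sulforhodamine B assay, with a stated time of 48 h; on this read-out higher numbers stand for weaker inhibition and lower numbers for stronger inhibition:
- compound 1 `COc1cccc(/C=C/C(=O)c2c(O)cc(OC)cc2OC)c1`: 3100 nM
- compound 2 `COc1cc(O)c(C(=O)/C=C/c2cccc(OC)c2OC)c(OC)c1`: 3500 nM
- compound 3 `COc1cc(OC)c(C(=O)/C=C/c2cccc(OC)c2OC)c(OCC=C(C)C)c1`: 11700 nM

Compound 2 cannot be told apart from compound 1, with a 1.1-fold higher number from compound 1 to compound 2 (0.05 log units; within the scatter). Compound 4 `COc1cc(O)c(C(=O)/C=C/c2cccc(OC)c2OC)c(OC)c1CC=C(C)C` is still unmeasured and adds one change to compound 2: 3-methylbut-2-en-1-yl in place of hydrogen on an aromatic carbon. It places 3-methylbut-2-en-1-yl on an aromatic carbon, para to a hydroxy group. Among the compounds with values here, the nearest precedent is compound 3, which carries this group on an oxygen on an aromatic ring, with a 3.3-fold higher number from compound 2 to compound 3 (0.52 log units; beyond the scatter). Within the data shown here, no measured step covers this group on an aromatic carbon, so that precedent transfers only loosely. A modest rise in this assay is expected, smaller than the precedent, with a wide margin. The expected step is a 1.4-fold higher number from compound 2 to compound 4 (0.15 log units; within the scatter). For compound 4 the estimated value is 5000 nM, with an expected range of 1500 nM to 15000 nM.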

Compound 4, half-maximal inhibitory concentration: 29500 nM
Compound 4: middle estimate off by 5.9-fold (0.77 log units), on the low side; measured number above the stated range.
By their numbers in this assay, from the lowest: compounds 1 and 2 (each within the scatter of the next); then compound 3; then compound 4.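

In this assay, placing 3-methylbut-2-en-1-yl on the aromatic carbon para to a hydroxy group weakens inhibition clearly (an 8.4-fold higher number from compound 2 to compound 4 (0.93 log units; beyond the scatter)). The same group on an oxygen on an aromatic ring gives a smaller printed step (a 3.3-fold higher number from compound 2 to compound 3 (0.52 log units; beyond the scatter)), so attachment point matters alongside the group itself. This aromatic carbon, ortho to two methoxy groups, is therefore not a neutral site for this chain.

As far as these compounds go, whether an amine or a carboxylic acid at this carbon would be tolerated remains open. No supporting data explain the size of this step.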